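Notes on the amide side chain and transporter binding

The source may report more compounds than this note shows. Statements on the series, on what has been measured and on what is new or still open speak of the compounds shown alone.

For the measured compounds named here, compound 2 `CC(C)(C)OC(=O)NCCCNC(=O)CN1CN(c2ccccc2)C2(CCN(C(=O)c3ccc(C(C)(C)C)cc3)CC2)C1=O` gives 4500 nM in an assay on HEK293 cells for displacement of a labelled ligand from NPC1-like intracellular cholesterol transporter 1 (Homo sapiens) (on this read-out lower numbers stand for stronger inhibition and higher numbers for weaker inhibition), the second highest of the three numbers measured so far; compound 1 `CC(C)(C)OC(=O)NCCCNC(=O)CN1CN(c2ccccc2)C2(CCN(C(=O)c3ccc(C4CCCCC4)cc3)CC2)C1=O` gives 6000 nM, a 1.3-fold lower number from compound 1 to compound 2 (0.12 log units; within the scatter), and compound 3 `CC1(C)CC(OC(=O)CN2CN(c3ccccc3)C3(CCN(C(=O)c4ccc(C5CCCCC5)cc4)CC3)C2=O)CC(C)(C)N1` gives 600 nM. Compound 4 `CC1CCCN(C(=O)CN2CN(c3ccccc3)C3(CCN(C(=O)c4ccc(C(C)(C)C)cc4)CC3)C2=O)C1` differs from compound 2 at one place: 3-methylpiperidin-1-yl in place of (3-((tert-butoxycarbonyl)amino)propyl)amino on a carbonyl carbon. Going by the values given here, the only measured step at this carbonyl carbon is a 10-fold lower number from compound 1 to compound 3 (1.00 log units; beyond the scatter), which exchanged the same leaving group for a different ring-bearing group; no measured step covers a 3-methylpiperidin-1-yl group. A lower number for compound 4 in this assay is therefore expected, though of smaller size than that step, given the different entering group. The expectation for compound 4 is 2000 nM, with a range from 700 nM to 6000 nM, which means an estimated 2.3-fold lower number from compound 2 to compound 4 (0.35 log units; beyond the scatter).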

Compound 4, half-maximal inhibitory concentration: 12000 nM
The estimate for compound 4 lay 6.0-fold (0.78 log units) below the measured number; measured number outside the range, above it.
By their numbers in this assay, from the lowest: compound 3; then compounds 2, 1 and 4 (each within the scatter of the next, the first and the last beyond it).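

In this assay, 3-methylpiperidin-1-yl in place of (3-((tert-butoxycarbonyl)amino)propyl)amino gives a 2.7-fold higher number from compound 2 to compound 4 (0.43 log units; beyond the scatter), the opposite direction to a 10-fold lower number from compound 1 to compound 3 (1.00 log units; beyond the scatter), so losing the leaving group does not by itself lower the number. A six-membered ring in the entering group is also not enough to lower it, although these two steps were measured with different groups on the aromatic carbon, tert-butyl and cyclohexyl. No available evidence accounts for the rise.

From the compounds shown here alone, it remains open whether (2,2,6,6-tetramethylpiperidin-4-yl)amino, with nitrogen in place of the ester oxygen, would keep the lower number, and how a free primary amine at the end of the propyl chain would behave.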